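The compounds below may be only part of what the source reports. "The series", "measured", "known", "first", "only" and "open" are said of these compounds alone.

Measured compounds:
compound 1, `O=C1/C(=C/c2cccc(F)c2)CN(S(=O)(=O)c2ccccc2)C/C1=C\c1cccc(F)c1`, 3400 nM in a functional assay on HepG2 cells (Homo sapiens) for cytotoxicity, read by MTT assay, with a stated time of 24 h; a higher number here means a weaker inhibitor, a lower number a stronger inhibitor
compound 2, `Cc1ccc(S(=O)(=O)N2C/C(=C\c3cccc(F)c3)C(=O)/C(=C/c3cccc(F)c3)C2)cc1`, 3500 nM
compound 3, `O=C1/C(=C/c2ccc(F)cc2)CN(S(=O)(=O)c2ccccc2)C/C1=C\c1ccc(F)cc1`, 18800 nM

Compound 1 and compound 2 share a core and differ by one change, (methyl in place of hydrogen on an aromatic carbon). That change gives a 1.0-fold higher number from compound 1 to compound 2 (0.01 log units; within the scatter), so the two values sit within the scatter of each other and no order between compound 1 and compound 2 can be read from them.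

Compound 3 carries the same atoms as compound 1, joined differently; the difference between the two cores is not broken down here. In this assay compound 3 gives the highest of the three numbers, and its gap to compound 2 and to compound 1 lies beyond the scatter in both cases.

Compound 4, `Cc1ccc(S(=O)(=O)N2C/C(=C\c3ccc(F)cc3)C(=O)/C(=C/c3ccc(F)cc3)C2)cc1`, is not yet measured. It differs from compound 3 by methyl in place of hydrogen on an aromatic carbon, which is the same change as that from compound 1 to compound 2, made on the core of compound 3 instead. Within the data shown here, only one measured instance of this change exists, so the expectation rests on a single pair. Because a 1.0-fold higher number from compound 1 to compound 2 (0.01 log units; within the scatter) was within the scatter, the step from compound 3 to compound 4 is expected to be likewise small, no change at the digits printed from compound 3 to compound 4 (within the scatter). Among the measured compounds shown here, the estimate for compound 4 in this assay is therefore 18800 nM, with a likely range from 9000 nM to 40000 nM, the width reflecting that compound 3 alone anchors the core and only one pair anchors the change.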

Compound 4, half-maximal inhibitory concentration: 4500 nM
Beside the measured number, compound 4's estimate is 4.2-fold (0.62 log units) above it; measured number outside the range, below it.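

In this assay methyl in place of hydrogen on an aromatic carbon gives a 1.0-fold higher number from compound 1 to compound 2 (0.01 log units; within the scatter) on the core of compound 1 and a 4.2-fold lower number from compound 3 to compound 4 (0.62 log units; beyond the scatter) on the core of compound 3. The change therefore does not carry across these two cores at one size, so a step read on one of them is a poor guide to the other: the same change on two cores in this assay, a 1.0-fold higher number (0.01 log units; within the scatter) from compound 1 to compound 2 and a 4.2-fold lower number (0.62 log units; beyond the scatter) from compound 3 to compound 4, 4.3-fold (0.63 log units) apart, beyond the scatter of two such steps.
This shows only that phenylsulfonyl to (4-methylphenyl)sulfonyl behaves differently on two cores in one cytotoxicity read-out; with a single pair on each core, it does not show why the steps differ, nor does it give a rule for any further core.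

Still open, from the compounds shown here alone, is whether the difference between the cores is particular to methyl or also appears with other groups at the same place on the ring, such as ethyl, methoxy, chloro or an amine. Also open, going by these compounds, is whether a carboxylic acid or a longer chain there would give steps that agree across the two cores or that diverge as these do.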